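Methyl removal on the fused ring of compound 2

This account rests on a few compounds, and the source may have more. Where it says the series, first, only, none or still open, it means among the compounds named here.

Three compounds on a shared core have numbers in a functional assay, read by spectrophotometry, with a stated time of 1 h; a lower number here means a stronger inhibitor, a higher number a weaker inhibitor. Compound 2 `Cc1ccc2[nH]c(=O)c(/C=N/Nc3ccc([N+](=O)[O-])cc3)cc2c1` gives 350000 nM. Compound 1 `CCCC/N=C/c1cc2cc(C)ccc2[nH]c1=O` gives 3560000 nM, and compound 3 `NS(=O)(=O)CC(=O)N/N=C/c1cc2ccccc2[nH]c1=O` gives 8730000 nM. Compound 2 has the lowest number of the three; its gaps to compound 1 and to compound 3 both lie beyond the scatter, so on these numbers compound 2 is the strongest inhibitor of the set. Compound 4 `O=c1[nH]c2ccccc2cc1/C=N/Nc1ccc([N+](=O)[O-])cc1` is not yet measured. Its change from compound 2 is hydrogen in place of methyl on an aromatic carbon. For the measured compounds named here, no measured pair shows this step, so its size rests on no direct comparison within the set. The expectation is a small step, not clearly beyond the scatter, leaning toward a slightly higher number. Compound 4 is therefore expected to give 450000 nM, within a range of 150000 nM to 1500000 nM. The step from compound 2 to compound 4 is expected to be a 1.3-fold higher number from compound 2 to compound 4 (0.11 log units; within the scatter), a change that would stay close to the scatter.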

Compound 4, half-maximal inhibitory concentration: 245000 nM
The estimate for compound 4 lay 1.8-fold (0.26 log units) above the measured number, and the stated range covers the measured number.
By their numbers in this assay, from the lowest: compounds 4 and 2 (each within the scatter of the next); then compound 1; then compound 3.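

For the compounds shown here, the pair gives the only direct reading of this change. In this assay, hydrogen in place of methyl on an aromatic carbon gives a 1.4-fold lower number from compound 2 to compound 4 (0.15 log units; within the scatter), and this step lies within the scatter. The methyl at this carbon is thus not required for a number of this size with this side chain, and compound 2 and compound 4 cannot be separated. Nothing available bears on the reason for this result.

From the compounds shown here alone, how a longer chain, a methoxy group or an amine on this aromatic carbon would read remains open. Also open, going by these compounds, is whether removing the methyl would read alike with the side chain of compound 1, which has no partner here that differs from it in one place.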